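Phosphate chain extension in the dithiocarbamate phosphate series

The source may report more compounds than this note shows. Statements on the series, on what has been measured and on what is new or still open speak of the compounds shown alone.

Compound 1 `CCCOP(=O)(O)OCCSC(=S)N1CCCC1`: > 100000 nM
Compound 2 `CCCOP(=O)(O)OCCSC(=S)N1CCCCCC1`: 54000 nM

In an ADME assay on HEK293 cells (Homo sapiens) for inhibition, read by MTT assay, with stated times of 18 h and 4 h (on this read-out lower numbers stand for stronger inhibition and higher numbers for weaker inhibition), compound 1 gives > 100000 nM, a limit of the measurement and not a number; compound 1 stands at the limit of > 100000 nM in this assay, at which 1 of the 2 values shown sits. In this assay, among the compounds with values here, compound 2 gives 54000 nM, the only number so far. Compound 3 `CCCCCCCCCCOP(=O)(O)OCCSC(=S)N1CCCCCC1` differs from compound 2 by heptyl in place of hydrogen on a saturated chain carbon, three bonds along the chain from an oxygen on an unsaturated carbon. Within the data shown here, no measured step of this kind exists in the set. The step of a 3.6-fold lower number from compound 2 to compound 3 (0.56 log units; beyond the scatter) is expected to run toward stronger inhibition, beyond the usual scatter. Compound 3 is estimated at 15000 nM, with a range from 4000 nM to 50000 nM.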

Compound 3, half-maximal inhibitory concentration: 70000 nM
Compound 3: the middle estimate sits 4.7-fold (0.67 log units) below what was measured; measured number above the stated range.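

In this assay the record reads a 1.3-fold higher number from compound 2 to compound 3 (0.11 log units; within the scatter) and so heptyl in place of hydrogen on a saturated chain carbon, three bonds along the chain from an oxygen on an unsaturated carbon, leaves the read-out within the scatter. Within the data shown here, this position therefore accepts heptyl with no readable change in inhibition, something the earlier compounds could not show. Nothing measured here bears on why the number holds.

As far as these compounds go, whether a butyl chain, or an amine or a carboxylic acid at the chain end, would shift the number stays open. So does whether a longer chain at this position would do so.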